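The source may report more compounds than this note shows. Statements on the series, on what has been measured and on what is new or still open speak of the compounds shown alone.

Working notes on the series, read in an ADME assay on the whole organism (Rattus norvegicus, strain Sprague-Dawley) for pharmacokinetics, read by LC-MS, with a stated time of 30 min, at a dose of 1 mg/kg by the intravenous route (on this read-out lower numbers stand for slow clearance and higher numbers for fast clearance), for compounds that share one core and differ on the sulfonyl sulfur. Compound 1 (`N#Cc1ccc(O[C@H]2CN(S(=O)(=O)c3ccc(C(F)(F)F)cc3)C[C@@]2(O)CO)cc1F`) gives 50 mL/min/kg and compound 2 (`N#Cc1ccc(O[C@H]2CN(S(=O)(=O)c3ccccc3C#N)C[C@@]2(O)CO)cc1F`) gives 39 mL/min/kg on this read-out. These two values lie within the scatter of each other, so compound 2 stands level with compound 1 on the numbers at hand.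

The next change leads to compound 3 (`N#Cc1ccc(O[C@H]2CN(S(=O)(=O)c3ccc(Cl)cn3)C[C@@]2(O)CO)cc1F`), with 5-chloropyridin-2-yl in place of 2-cyanophenyl on a sulfonyl sulfur as the counted difference: 5-chloropyridin-2-yl in place of 2-cyanophenyl on a sulfonyl sulfur. Among the measured compounds shown here, one measured step bears on it, a 1.3-fold lower number from compound 1 to compound 2 (0.11 log units; within the scatter), which is a replacement at the same place and stays small. For the measured compounds named here, no measured compound yet carries 5-chloropyridin-2-yl, so that single step is a thin guide and the range has to stay wide.

No step beyond the scatter is expected in this assay, and the estimated move is a 1.1-fold higher number from compound 2 to compound 3 (0.03 log units; within the scatter) as things stand. For compound 3 the expected clearance is 42 mL/min/kg with an estimated range from 23 mL/min/kg to 72 mL/min/kg at this dose.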

Compound 3, clearance: 30 mL/min/kg
For compound 3 the middle estimate is 1.4-fold (0.15 log units) above the measured one; measured number inside the range.
By their numbers in this assay, from the lowest: compounds 3, 2 and 1 (each within the scatter of the next).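

In this assay, among the compounds shown here, the sulfonyl sulfur now carries a third kind of group, and 5-chloropyridin-2-yl, the only one of the three rings with a hetero atom, gives a 1.3-fold lower number from compound 2 to compound 3 (0.11 log units; within the scatter) and a 1.7-fold lower number from compound 1 to compound 3 (0.22 log units; within the scatter). Neither step leaves the scatter, so with the step between compound 1 and compound 2 also inside it, compounds 1, 2 and 3 stand level and exchanging one of these aromatic rings for another at this place has no readable effect on clearance in this set, even with a ring hetero atom and a chlorine entering and the nitrile or trifluoromethyl leaving. No supporting measurement at hand bears on this result, and the numbers alone offer no explanation for it.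

Going by these compounds, all three groups on the sulfonyl sulfur are six-membered aromatic rings, so it remains open whether a non-aromatic group there, such as a short alkyl chain, or an aromatic ring carrying an amine or a carboxylic acid, would give a step beyond the scatter. On these data alone, the separate contributions of the ring nitrogen and the chlorine in 5-chloropyridin-2-yl also remain open.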